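Notes on compound 3: replacing the amide-linked chain

This account rests on a few compounds, and the source may have more. Where it says the series, first, only, none or still open, it means among the compounds named here.

compound 1 `CC(=O)Oc1ccccc1C(=O)NCC[Se]C#N` at 3400 nM in this series
compound 2 `CC(=O)Oc1ccccc1C(=O)[Se]CC[Se]C(=O)c1ccccc1OC(C)=O` at 18600 nM in this series

Both values come from a functional assay on HT-29 cells (Homo sapiens) for antiproliferative activity, read by MTT assay, with a stated time of 24 h (on this read-out lower numbers stand for stronger inhibition and higher numbers for weaker inhibition), and compound 1 has the lower number of the two, with compound 2 higher by a gap beyond the scatter. Compound 3 `CC(=O)Oc1ccccc1C(=O)[Se]CC[Se]C#N` is still unmeasured. Its change from compound 1 is a group of 6 heavy atoms (3 carbon, 1 nitrogen, 2 selenium; no ring) in place of a group of 6 heavy atoms (3 carbon, 2 nitrogen, 1 selenium; no ring), on a carbonyl carbon on a carbonyl carbon, with a group of 6 heavy atoms in place of another group of 6 heavy atoms. For the measured compounds named here, no measured step covers this change, so the expectation is loose. A modest rise in this assay is expected, possibly no larger than the scatter, with compound 2 at 18600 nM as the only higher reference. The expected step of a 1.5-fold higher number from compound 1 to compound 3 (0.17 log units; within the scatter) is therefore small and upward. Compound 3 is estimated at 5000 nM as a middle value, with an expected range of 1800 nM to 14000 nM around it.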

Compound 3, half-maximal inhibitory concentration: > 50000 nM
Compound 3 was reported as a limit (the forecaster's own chance of this, stated with the estimate: 3%); middle value at least 10-fold (1.00 log units) from the limit.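

In this assay, for the compounds shown here, this is the first measured step at the carbonyl carbon whose other neighbours are aromatic carbon, and it runs an at least 14-fold higher number from compound 1 to compound 3 (1.16 log units; beyond the scatter). Compound 3 carries a limit, not a number: the limit of > 50000 nM in this assay, at which 1 of the 3 values shown sits. The position therefore does not tolerate every group of this size: both groups have 6 heavy atoms, no ring and 1 triple bond, yet the entering group, with 2 selenium and 0 hydrogen-bond donors in place of 1 selenium and 1 hydrogen-bond donor, goes with a large upward step.

The selenium on the carbonyl carbon and the loss of the amide hydrogen arrive together here, and the compounds shown cannot separate them. As far as these compounds go, an ester oxygen or a methylated amide nitrogen at this place, or a longer chain on the amide, remains open.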